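The compounds below may be only part of what the source reports. "The series", "measured", "known", "first", "only" and "open" are said of these compounds alone.

Three compounds built on the shared core of compound 1 `Cc1ccccc1Oc1ccc(CC2SC(=O)NC2=O)cc1` have been measured in a functional assay for agonist activity at Free fatty acid receptor 1 (Homo sapiens), read by FLIPR, in the presence of a further agent that is not named here; on this read-out lower numbers stand for an effect already at smaller amounts and higher numbers for an effect only at larger amounts of compound. Compound 1 gives 124 nM, compound 2 `Cc1cccnc1Oc1ccc(CC2SC(=O)NC2=O)cc1` gives 1090 nM, and compound 3 `O=C1NC(=O)C(Cc2ccc(Oc3ccc(F)cc3)cc2)S1` gives 480 nM, which places compound 3 second highest of the three, nearer to compound 2 than to compound 1. Compound 4 `Cc1cccc(Oc2ccc(CC3SC(=O)NC3=O)cc2)c1` differs from compound 3 by 3-methylphenyl in place of 4-fluorophenyl on an oxygen on an aromatic ring. Because a 3.9-fold higher number from compound 1 to compound 3 (0.59 log units; beyond the scatter) compares a methylphenyl with the 4-fluorophenyl on that oxygen, that step bears most here; an 8.8-fold higher number from compound 1 to compound 2 (0.94 log units; beyond the scatter) and a 2.3-fold lower number from compound 2 to compound 3 (0.36 log units; beyond the scatter) show the same position moving the read-out. Compound 4 is therefore expected to give a modestly lower number, a 1.9-fold lower number from compound 3 to compound 4 (0.28 log units; within the scatter). The estimate for compound 4 is 250 nM, with a range from 100 nM to 600 nM.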

Compound 4, half-maximal effective concentration: 203 nM
The estimate for compound 4 lay 1.2-fold (0.09 log units) above the measured number; the measured number falls inside the stated range.
By their numbers in this assay, from the lowest: compounds 1 and 4 (each within the scatter of the next); then compound 3; then compound 2.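

Against the 4-fluorophenyl and the 3-methylpyridin-2-yl, the 3-methylphenyl on this oxygen lowers the number in this assay (with a 2.4-fold lower number from compound 3 to compound 4 (0.37 log units; beyond the scatter) and a 5.4-fold lower number from compound 2 to compound 4 (0.73 log units; beyond the scatter)). The two methylphenyl groups cannot be told apart (with a 1.6-fold higher number from compound 1 to compound 4 (0.21 log units; within the scatter)), so this result gives no sign that the place of the methyl on the phenyl ring matters between compound 1 and compound 4. Nothing available here accounts for these differences. As far as these compounds go, it stays open whether an ethyl group, a methoxy group or a carboxylic acid in place of the methyl would keep the number this low.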